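This account rests on a few compounds, and the source may have more. Where it says the series, first, only, none or still open, it means among the compounds named here.

Compound 1 `COc1cc(-c2cnc(N)nc2-c2ccccc2)cc(OC)c1OC`: 56%
Compound 2 `O=C(Nc1ncc(-c2cccc(Cl)c2)c(-c2ccccc2)n1)C1CCC1`: 52%

In an assay on CHO cells for displacement of a labelled ligand from adenosine receptor A1 (Homo sapiens), read by scintillation counting, with a stated time of 1 h, tested at 1 uM (on this read-out higher numbers stand for more inhibition at the one concentration tested (going by the name of the read-out) and lower numbers for less inhibition), compound 2 and compound 1 lie within the usual scatter of each other, so the two cannot be told apart on these numbers. Compound 3 `CCCCNc1ncc(-c2cccc(Cl)c2)c(-c2ccccc2)n1` differs from compound 2 in one place: butyl in place of cyclobutylcarbonyl on a nitrogen on an aromatic ring. Within the data shown here, no measured pair shows a change of this kind, so there is no step to calibrate against, and the expected step of a number 7 percentage points lower from compound 2 to compound 3 (within the scatter) is taken to be none beyond the scatter, though with wide uncertainty. The estimate for compound 3 is 45%, with a range from 20% to 70%.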

Compound 3, a percentage reported as inhibition, at one concentration (the size of the read-out at that concentration, not a potency): 56%
Compound 3: the middle estimate sits 11 percentage points below what was measured, within the range that was stated.
By their numbers in this assay, from the lowest: compounds 2, 1 and 3 (each within the scatter of the next).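

In this assay, butyl in place of cyclobutylcarbonyl on a nitrogen on an aromatic ring gives a number 4 percentage points higher from compound 2 to compound 3 (within the scatter) and so leaves the read-out unresolved. Thus, at this one concentration, the cyclobutylcarbonyl group, with its ring and carbonyl, can be exchanged for a plain butyl chain without a measurable difference. No measurement available here offers an explanation for this. Still open, going by these compounds, is how a longer chain, such as octyl, would read on this nitrogen. On these data alone, a carboxylic acid at the end of the butyl chain is equally open.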